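The source may hold more compounds than are shown below. What is called first, only, known or untested is meant among the compounds shown, and "the series" means these compounds.

Measured so far in a functional assay on MGC-803 cells (Homo sapiens) for cytotoxicity, read by MTT assay, with a stated time of 3 days; on this read-out lower numbers stand for stronger inhibition and higher numbers for weaker inhibition:
- compound 1 `Cc1cc(C)nc(Sc2ccc(NC(=O)Nc3ccccc3)cc2)n1`: 40100 nM
- compound 2 `Cc1cc(C)nc(Sc2ccc(NC(=O)Nc3ccc(OC(F)(F)F)cc3)cc2)n1`: 13800 nM

For the measured compounds named here, compound 1 stands highest of the two numbers; the only neighbour is compound 2, reached by a 2.9-fold lower number from compound 1 to compound 2 (0.46 log units; beyond the scatter), a modest lowering from a single change on the terminal phenyl ring.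

Compound 3 `Cc1cc(C)nc(Sc2ccc(NC(=O)Nc3ccc(Cl)cc3Cl)cc2)n1` differs from compound 1 by 2,4-dichlorophenyl in place of phenyl on an amide-type nitrogen. Going by the values given here, the one step that bears on it, a 2.9-fold lower number from compound 1 to compound 2 (0.46 log units; beyond the scatter), shows that adding a group to this ring lowered the number beyond the scatter. A lowering of similar size is therefore expected for compound 3, estimated as a 2.7-fold lower number from compound 1 to compound 3 (0.43 log units; beyond the scatter), giving 15000 nM with a range from 6000 nM to 40000 nM.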

Compound 3, half-maximal inhibitory concentration: > 50000 nM
Compound 3 gave a limit, no number; the forecaster's own chance of this, stated with the estimate: 5%; at least 3.3-fold (0.52 log units) between middle value and limit.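

Compound 3 in this assay carries a limit of the assay and not a number: the limit of > 50000 nM in this assay, at which 1 of the 3 values shown sits. The step to it reads an at least 1.2-fold higher number from compound 1 to compound 3 (0.09 log units; that floor lies within the scatter), so this change on the amide-type nitrogen brings no lowering like a 2.9-fold lower number from compound 1 to compound 2 (0.46 log units; beyond the scatter), though its floor does not separate the two compounds. Adding groups to this ring therefore does not lower the number in every case, and compound 3 goes against compound 2.

From the compounds shown here alone, what 4-chlorophenyl or 2-chlorophenyl alone would give in this place stays open. So does the effect of a carboxylic acid or an amine on this ring.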